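A few compounds are considered here, and "the series" means these few. Any claim that something is new, unique, unknown or untested is made for them only; others in the source may bear on it.

Compound 2 `O=C(CC1c2ccccc2N=C(SCCCCCN2CCCC2)N1c1ccccc1)NCc1ccccc1` has the higher of the two numbers recorded in this series: in an assay on cells for inhibition of Voltage-dependent T-type calcium channel subunit alpha-1I (Homo sapiens), read by patch clamp, tested at 10 uM (on this read-out lower numbers stand for less inhibition and higher numbers for more inhibition at the one concentration tested (going by the name of the read-out)), compound 2 gives 78.3%. Its nearest neighbour, compound 1 `O=C(CC1c2ccccc2N=C(SCCCCCN2CCCC2)N1c1ccc(-c2ccccc2)cc1)NCc1ccc(F)cc1`, carries a fluorine on the benzyl group and a phenyl on the aryl group bound to the core nitrogen; in this assay compound 1 gives 55.9%, a number that lies well beyond the usual scatter below compound 2. Because compound 1 differs from compound 2 in two places, the two values alone cannot say which of the two changes carries the drop.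

Compound 3 `O=C(CC1c2ccccc2N=C(SCCCCCN2CCCC2)N1c1ccc(-c2ccccc2)cc1)NCc1ccccc1` takes one of those changes and leaves the other out: relative to compound 2 the difference is phenyl in place of hydrogen on an aromatic carbon. Compound 3 therefore shares the 4-phenylphenyl group with compound 1 but keeps the plain benzyl amide of compound 2.

Since compound 1 with 55.9% already shows what the two changes together do, the step from compound 2 to compound 3 is expected to point downward, by a number 14.3 percentage points lower from compound 2 to compound 3 (beyond the scatter). Compound 3 is estimated to give 64% in this assay, with a likely range from 47% to 80%.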

Compound 3, a percentage reported as inhibition, at one concentration (the size of the read-out at that concentration, not a potency): 92.7%
The estimate for compound 3 lay 28.7 percentage points below the measured number; measured number outside the range, above it.
By their numbers in this assay, from the lowest: compound 1; then compound 2; then compound 3.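

Compound 3 shows that the phenyl added to the aryl group on the core nitrogen, on an aromatic carbon para to a large group, does not lower the number in this assay: the change from phenyl to 4-phenylphenyl gives a number 14.4 percentage points higher from compound 2 to compound 3 (beyond the scatter). With the 4-phenylphenyl group held fixed, the benzyl fluorine can now be read on its own, and hydrogen in place of fluoro on an aromatic carbon gives a number 36.8 percentage points higher from compound 1 to compound 3 (beyond the scatter), so within this pair the low number of compound 1 goes with the fluoro group and not with the added phenyl. Nothing shown bears on why either step runs as it does.

Going by these compounds alone, the fluoro step has been seen only with the 4-phenylphenyl group present, so what a fluoro group does to the benzyl amide of compound 2 stays open. Also open, from the compounds shown here alone, is whether a methyl, a chloro or a pyridyl group at the same place would go the way of the phenyl, and whether any of these steps would hold as potencies, given that each number comes from a single concentration.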